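From Chloro to Acetyl: Expected Tolerance of Compound 3

This account rests on a few compounds, and the source may have more. Where it says the series, first, only, none or still open, it means among the compounds named here.

Measured compounds:
compound 1, `O=S(=O)(NCc1csc2ccccc12)c1ccc(Cl)cc1`: 69600 nM
compound 2, `O=S(=O)(NCc1csc2ccccc12)c1cccc(F)c1`: "not determined" (no result reported)

Two compounds share a common core and have been examined in an ADME assay on MDCK cells (Canis lupus familiaris) for cytotoxicity, read by MTT assay, with a stated time of 24 h; a higher number here means that more compound is tolerated, a lower number that less compound is tolerated. Compound 1 gives 69600 nM in this assay. Among the measured compounds shown here, compound 2 gives "not determined" (no result reported) in this assay, so compound 1 stands alone as the only value available, and nothing about order between the two can be said. The assay reports how much compound cells can tolerate; a large number means little cytotoxicity at the concentrations tried.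

Compound 3, `CC(=O)c1ccc(S(=O)(=O)NCc2csc3ccccc23)cc1`, has not been measured. Compared with compound 1, the change is acetyl in place of chloro on an aromatic carbon. For the measured compounds named here, no step between two measured compounds in this assay exists here, so there is nothing to calibrate against. For a single group exchanged on the outer ring with the rest of the molecule unchanged, the step from compound 1 to compound 3 is expected to stay close to the scatter, with no clear direction: a 1.1-fold higher number from compound 1 to compound 3 (0.06 log units; within the scatter). Compound 3 is therefore expected to give about 80000 nM, within a range from 35000 nM to 160000 nM.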

Compound 3, half-maximal cytotoxic concentration: > 193000 nM
Compound 3: a limit, no number; the forecaster's own chance of this, stated with the estimate: 30%; middle value at least 2.4-fold (0.38 log units) from the limit.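

In this assay compound 3 gives > 193000 nM, which is a limit of the assay and not a number. Among the compounds shown here, putting acetyl in place of chloro on this aromatic carbon, para to a large group, gives an at least 2.7-fold higher number from compound 1 to compound 3 (0.44 log units; beyond the scatter), so this is the first sign that, with the shared core left unchanged, the group at this position can shift the reading by more than ordinary repeat variation. How far the step really reaches cannot be read from a limit: the limit of > 193000 nM in this assay, at which 1 of the 3 values shown sits.

Steps involving compound 2 cannot be read, so the comparison rests on a single pair, and it cannot separate what acetyl brings from what the loss of chloro removes. On these data alone, whether the higher number is special to acetyl also stays open, and an amine, a carboxylic acid or a longer chain at the same position would be needed to show whether other groups move the reading in the same direction or leave it near that of compound 1.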